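The source may report more compounds than this note shows. Statements on the series, on what has been measured and on what is new or still open speak of the compounds shown alone.

Working notes on the series. The shared core of compound 1 `CC(C)(C)C1=C(C(=O)O)N2C(=O)[C@H](CO)[C@H]2O1` carries a hydroxymethyl group, and in an ADME assay, in phosphate buffer, at 28 degrees C, at pH 7.0 (a lower number here means that the compound disappears faster, a higher number that the compound lasts longer), compound 1 gives 5 h. Among the compounds with values here, this is the lowest of the two numbers measured so far. The nearest measured neighbour is compound 2 `CC(C)(C)C1=C(C(=O)O)N2C(=O)[C@H]([C@@H](O)c3ccc(O)cc3)[C@H]2O1`, which in this assay gives 10.3 h; the step of a 2.1-fold higher number from compound 1 to compound 2 (0.31 log units; beyond the scatter) is beyond the scatter but modest, and it comes from a 4-hydroxyphenyl in place of hydrogen on a saturated chain carbon bound to an oxygen on a saturated carbon and a saturated ring carbon, a change at a different place from the one now under consideration.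

Compound 3 `CC(=O)NC[C@H]1C(=O)N2C(C(=O)O)=C(C(C)(C)C)O[C@H]12` differs from compound 1 by acetamido in place of hydroxy on a saturated chain carbon bound to a saturated ring carbon. Within the data shown here, no measured step touches this position, so the only guide is that the single change seen so far, from compound 1 to compound 2, moved the half-life only modestly. For compound 3 no step beyond the scatter is expected in this assay, that is, a change of about a 1.1-fold higher number from compound 1 to compound 3 (0.04 log units; within the scatter) from compound 1 is expected. The half-life of compound 3 is therefore estimated at 5.5 h, with a range of 2.5 h to 12 h.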

Compound 3, half-life: < 3 h
Compound 3: only a limit was reported; the forecaster's own chance of this, stated with the estimate: 5%; middle value at least 1.8-fold (0.26 log units) from the limit.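

At the saturated chain carbon bound to a saturated ring carbon, in this assay, acetamido in place of hydroxy gives an at least 1.6-fold lower number from compound 1 to compound 3 (0.22 log units; that floor lies within the scatter). Within the data shown here, this is the first reading of a change at this position, and it points towards faster disappearance rather than the near-unchanged half-life that the earlier compounds left as the only guide, though the floor alone does not establish a real difference. Compound 3 gives < 3 h, which is a limit of the assay and not a number, so the step can only be read as a floor: the limit of < 3 h in this assay, at which 1 of the 3 values shown sits.

Going by these compounds, how far compound 3 truly lies from compound 1 stays open, and so does whether the result follows from the acetamido group as a whole or from some part of it, since hydroxy and acetamido have the same hydrogen-bond donor and acceptor counts and differ in heavy atoms and the added double bond. Also open is how an amine, a carboxylic acid or a longer chain would behave on this same chain carbon, as the compounds shown give no reading for any of them.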